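Fluoro to hydroxy on the aryl ring of compound 1

The compounds below may be only part of what the source reports. "The series", "measured", "known", "first", "only" and "open" are said of these compounds alone.

Compound 1 `COc1ccc(C2=C(c3cc(OC)c(OC)c(OC)c3)C(=O)C(OC(C)=O)C2)cc1F` carries a 3-fluoro-4-methoxyphenyl group on the shared core. In an ADME assay on ECV-304 cells (Homo sapiens) for cytotoxicity, read by MTT assay, with a stated time of 72 h (a higher number here means a weaker inhibitor, a lower number a stronger inhibitor), compound 1 gives 41 ug/mL, the highest of the three numbers. Compound 2 `COCOc1cc(C2=C(c3cc(OC)c(OC)c(OC)c3)C(=O)CC2O[SiH2]C(C)(C)C)ccc1OC` gives 40 ug/mL, within the scatter of compound 1. Compound 3 `COc1ccc(OC)c(C2=C(c3cc(OC)c(OC)c(OC)c3)C(=O)CC2O[SiH2]C(C)(C)C)c1` gives 6.5 ug/mL, beyond the scatter below compound 1. Going by the values given here, the one measured step on the series, a 6.2-fold lower number from compound 2 to compound 3 (0.79 log units; beyond the scatter), shows that an exchange of the aryl group can move this assay by a modest amount; it is a different exchange on a differently substituted core and does not directly address the change now in question.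

Compound 4 `COc1ccc(C2=C(c3cc(OC)c(OC)c(OC)c3)C(=O)C(OC(C)=O)C2)cc1O` differs from compound 1 by hydroxy in place of fluoro on an aromatic carbon. Among the compounds with values here, no measured pair exchanges fluoro for hydroxy, so the expectation rests on the small size of the change alone. For compound 4 a step of a 1.2-fold lower number from compound 1 to compound 4 (0.07 log units; within the scatter) is expected, that is, none beyond the scatter. Compound 4 is therefore estimated at 35 ug/mL, with a range from 15 ug/mL to 85 ug/mL.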

Compound 4, half-maximal inhibitory concentration: > 100 ug/mL
Compound 4 gave a limit, no number; the forecaster's own chance of this, stated with the estimate: 10%; middle value at least 2.8-fold (0.45 log units) away from the limit.
By their numbers in this assay, from the lowest: compound 3; then compounds 2 and 1 (each within the scatter of the next). At a limit, above all of these: compound 4.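

With hydroxy in place of fluoro on this aromatic carbon, ortho to a methoxy group, this assay shows an at least 2.4-fold higher number from compound 1 to compound 4 (0.38 log units; beyond the scatter), so a small exchange at this position is enough to move the read-out; the earlier step, a 6.2-fold lower number from compound 2 to compound 3 (0.79 log units; beyond the scatter), came from replacing a whole aryl group. The value of compound 4, > 100 ug/mL, is a limit and not a number. The new step therefore fixes only a minimum size for this change: the limit of > 100 ug/mL in this assay, at which 1 of the 4 values shown sits.

These two compounds cannot separate the effect of adding hydroxy from that of removing fluoro, and no property of either group is measured here. An amino or chloro group on the same carbon would test whether the higher number is particular to hydroxy.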